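The compounds below may be only part of what the source reports. "The series", "measured", "known", "first", "only" and "open" are said of these compounds alone.

Measured in a functional assay on HCT-116 cells (Homo sapiens) for inhibition, read by colorimetric assay, with a stated time of 3 days; on this read-out lower numbers stand for stronger inhibition and higher numbers for weaker inhibition:
- compound 1 `O=C(CCCCCCNC(=O)C(O)(O)C(F)(F)F)Nc1ncc(-c2ccc(Br)cc2)s1`: 2460 nM
- compound 2 `O=C(CCCCCCNC(=O)C(O)C(F)(F)F)Nc1nccs1`: > 40000 nM
- compound 3 `O=C(CCCCCCNC(=O)C(O)(O)C(F)(F)F)Nc1nc2ccccc2o1`: 3450 nM

Compound 2 gave only a limit, > 40000 nM.

Compound 3, at 3450 nM, lies within the usual scatter of compound 1, at 2460 nM. Compound 4 `COc1cccc(NC(=O)CCCCCCNC(=O)C(O)(O)C(F)(F)F)c1` carries 3-methoxyphenyl in place of 1,3-benzoxazol-2-yl on an amide-type nitrogen. Compound 1 and compound 3 differ at that same nitrogen yet stay within the scatter of each other, so no change beyond the scatter is expected in this assay, though compound 2 goes against this. The expected step is a 1.2-fold higher number from compound 3 to compound 4 (0.06 log units; within the scatter). For compound 4 the estimated value is 4000 nM, with an expected range of 1300 nM to 13000 nM.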

Compound 4, half-maximal inhibitory concentration: 6110 nM
Compound 4: the middle estimate sits 1.5-fold (0.18 log units) below what was measured; low and high end bracket the measured number.
By their numbers in this assay, from the lowest: compounds 1, 3 and 4 (each within the scatter of the next, the first and the last beyond it). At a limit, above all of these: compound 2.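

In this assay, 3-methoxyphenyl in place of 1,3-benzoxazol-2-yl on the amide-type nitrogen gives a 1.8-fold higher number from compound 3 to compound 4 (0.25 log units; within the scatter) and nothing beyond that. For the compounds shown here, this is the first step at this nitrogen that changes one place only, and it shows that the five-membered aromatic ring can leave without a change beyond the scatter. Nothing measured here bears on the reason for this step. As far as these compounds go, whether an amine or a carboxylic acid on the phenyl ring would hold at this nitrogen stays open. So does what a plain phenyl or a cyclohexyl group would give there.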